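Moving the Chlorine Along a Benzylsulfanyl Side Chain

The source may report more compounds than this note shows. Statements on the series, on what has been measured and on what is new or still open speak of the compounds shown alone.

Three compounds have been measured:
compound 1, `COc1ccc(C2N=C(SCc3ccccc3Cl)NC(C)=C2C(=O)Nc2ccc(F)cc2)cc1OC`, gives 39.2% in a functional assay on the whole organism (artery, strain albino) with Rattus norvegicus as the target, with a stated time of 360 min, at a dose of 10 mg/kg by the oral route; on this read-out lower numbers stand for less inhibition and higher numbers for more inhibition at the one dose given (going by the name of the read-out);
compound 2, `COc1ccc(C2N=C(SCc3cccc(Cl)c3)NC(C)=C2C(=O)Nc2ccc(F)cc2)cc1OC`, gives 20.1% in this assay;
compound 3, `CC1=C(C(=O)Nc2ccc(F)cc2)C(c2ccc([N+](=O)[O-])cc2)N=C(SCc2ccccc2Cl)N1`, gives 21.6% in this assay.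

Compounds 1 and 2 share one core and differ only by 3-chlorophenyl in place of 2-chlorophenyl on a saturated chain carbon bound to a sulfur. That change gave a number 19.1 percentage points lower from compound 1 to compound 2 (beyond the scatter). Compound 3 carries a different core; the difference from compound 1 is 4-nitrophenyl in place of 3,4-dimethoxyphenyl on a saturated ring carbon, and that change gave a number 17.6 percentage points lower from compound 1 to compound 3 (beyond the scatter). The values of compound 2 and compound 3 lie within the usual scatter of each other.

Compound 4, `CC1=C(C(=O)Nc2ccc(F)cc2)C(c2ccc([N+](=O)[O-])cc2)N=C(SCc2cccc(Cl)c2)N1`, is not yet measured. It differs from compound 3 by 3-chlorophenyl in place of 2-chlorophenyl on a saturated chain carbon bound to a sulfur, the same change made from compound 1 to compound 2, in the same place. Within the data shown here, for compound 4 the expected step is a number 11.6 percentage points lower from compound 3 to compound 4 (beyond the scatter), resting on compound 1 and compound 2 because of a number 19.1 percentage points lower from compound 1 to compound 2 (beyond the scatter), though only one such pair exists and the core differs. Compound 4 is therefore estimated at 10%, with a range from 0% to 25%.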

Compound 4, a percentage reported as inhibition, in the whole organism at one dose (the size of the read-out at that dose, not a potency): 21.1%
Compound 4: middle estimate off by 11.1 percentage points, on the low side; the range from low to high includes it.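

In this assay, 3-chlorophenyl in place of 2-chlorophenyl gave a number 0.5 percentage points lower from compound 3 to compound 4 (within the scatter), so the clear step seen on the core of compound 1 did not carry over to the core of compound 3: the same change on two cores in this assay, a number 19.1 percentage points lower (beyond the scatter) from compound 1 to compound 2 and a number 0.5 percentage points lower (within the scatter) from compound 3 to compound 4, 18.6 percentage points apart, beyond the scatter of two such steps

Seen from the other side, 4-nitrophenyl in place of 3,4-dimethoxyphenyl gave a number 1 percentage points higher from compound 2 to compound 4 (within the scatter), so that change also depended on the rest of the molecule: the same change on two cores in this assay, a number 17.6 percentage points lower (beyond the scatter) from compound 1 to compound 3 and a number 1 percentage points higher (within the scatter) from compound 2 to compound 4, 18.6 percentage points apart, beyond the scatter of two such steps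

Both gaps come from the same four compounds, so they are a single observation seen from two sides: the two changes do not simply add up in this set, but the data do not show why, or whether this holds beyond these compounds.

From the compounds shown here alone, it remains open how a plain phenyl or a longer chain between the sulfur and the chlorophenyl would behave on either core. Going by these compounds, each value also comes from a single oral dose and a single time, so it is unknown whether the same picture would hold at other doses or times.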